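The source may report more compounds than this note shows. Statements on the series, on what has been measured and on what is new or still open speak of the compounds shown alone.

Measured so far in an ADME assay on Vero cells (Chlorocebus sabaeus) for cytotoxicity, read by MTT assay, with a stated time of 48 h; on this read-out higher numbers stand for weaker inhibition and lower numbers for stronger inhibition:
compound 1 `O=c1nc(NCc2cccc(F)c2)oc2c([N+](=O)[O-])cc(C(F)(F)F)cc12`: compound 1 gives > 64 ug/mL, a limit of the assay.
compound 2 `O=c1cc(NCc2cccc(F)c2)sc2c([N+](=O)[O-])cc(C(F)(F)F)cc12`: compound 2 gives > 64 ug/mL, a limit of the assay.
compound 3 `O=c1cc(NCc2ccccc2)sc2c([N+](=O)[O-])cc(C(F)(F)F)cc12`: compound 3 gives > 64 ug/mL, a limit of the assay.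

Compound 3 therefore stands only at a limit in this assay, as do the other two values shown: the limit of > 64 ug/mL in this assay, at which 3 of the 3 values shown sit. Going by the values given here, the one measured step, a step that the two limits leave unreadable from compound 2 to compound 3, runs between two limits, and its size cannot be read. Compound 4 `O=c1cc(NCc2ccc(F)cc2)sc2c([N+](=O)[O-])cc(C(F)(F)F)cc12` differs from compound 3 by fluoro in place of hydrogen on an aromatic carbon. Among the compounds with values here, no measured step bears readably on this change, and with all values at the same limit no step beyond the scatter is expected in this assay in either direction. Compound 4 is expected to give 100 ug/mL, with a range from 50 ug/mL to 250 ug/mL, most likely reported again as a limit. The step this estimate implies, a step that the limit leaves unreadable from compound 3 to compound 4, is expected to be flat.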

Compound 4, half-maximal inhibitory concentration: > 64 ug/mL
Compound 4: only a limit was reported; the forecaster's own chance of this, stated with the estimate: 85%; the middle value is on the limit's open side.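

In this assay compound 4 gives > 64 ug/mL, a limit. The steps from compound 2 and compound 3 to compound 4 cannot be read: the limit of > 64 ug/mL in this assay, at which 4 of the 4 values shown sit. The compounds shown leave open at what concentration any of them reaches half-maximal inhibition, and whether fluoro in place of hydrogen changes it.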